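The compounds below may be only part of what the source reports. "The series", "measured", "known", "first", "only" and "open" are said of these compounds alone.

Compound 2 `CCN(CC)CCNC(=O)c1ccc(C(CC)(CC)c2ccc(OCS(=O)(=O)c3ccccc3)c(C)c2)n1CC` gives 4680 nM in a functional assay on MCF7 cells (Homo sapiens) for antiproliferative activity, read by MTT assay, with a stated time of 24 h (a higher number here means a weaker inhibitor, a lower number a stronger inhibitor), the lowest of the two numbers in hand. Compound 3 `CCn1c(C(=O)N[C@H](CO)CCCO)ccc1C(CC)(CC)c1ccc(OCS(=O)(=O)c2ccccc2)c(C)c1` gives 31400 nM, and the step of a 6.7-fold higher number from compound 2 to compound 3 (0.83 log units; beyond the scatter) is beyond the scatter. Compound 1 `CCn1c(C(=O)N[C@H](C)C(=O)OC)ccc1C(CC)(CC)c1ccc(OCS(=O)(=O)c2ccccc2)c(C)c1` reaches only the limit of this assay, > 50000 nM, and not a number (the limit of > 50000 nM in this assay, at which 1 of the 3 values shown sits). From that limit, the step of an at least 10-fold lower number from compound 1 to compound 2 (1.02 log units; beyond the scatter) is large, while the step of an at least 1.5-fold lower number from compound 1 to compound 3 (0.20 log units; that floor lies within the scatter) has a floor that lies within the scatter.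

Compound 4 `CCn1c(C(=O)N[C@H](C(=O)O)C(C)C)ccc1C(CC)(CC)c1ccc(OCS(=O)(=O)c2ccccc2)c(C)c1` is not yet measured. It differs from compound 2 by 1-carboxy-2-methylpropyl in place of 2-(diethylamino)ethyl on an amide-type nitrogen. For the measured compounds named here, the steps that bear on this change are an at least 10-fold lower number from compound 1 to compound 2 (1.02 log units; beyond the scatter) and a 6.7-fold higher number from compound 2 to compound 3 (0.83 log units; beyond the scatter): in both, the partner carrying 2-(diethylamino)ethyl on the amide-type nitrogen gave the lower number, and the partners carrying 1-(methoxycarbonyl)ethyl or the 1-hydroxy-4-hydroxybutan-2-yl-type chain gave higher numbers, one of them only a limit. The 1-carboxy-2-methylpropyl of compound 4 is closest in kind to the 1-(methoxycarbonyl)ethyl of compound 1, which sits at the limit. For compound 4 the expected step is an 8.5-fold higher number from compound 2 to compound 4 (0.93 log units; beyond the scatter), a large rise in this assay. Compound 4 is therefore estimated at 40000 nM, within 12000 nM to 150000 nM, with a real chance that only a limit is reported.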

Compound 4, half-maximal inhibitory concentration: 24500 nM
Estimate against measurement, compound 4: 1.6-fold (0.21 log units) above; low and high end bracket the measured number.
By their numbers in this assay, from the lowest: compound 2; then compounds 4 and 3 (each within the scatter of the next). At a limit, above all of these: compound 1.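

In this assay, compound 4 adds a third partner with a real number on the amide-type nitrogen, and the 2-(diethylamino)ethyl group keeps the lower number again, a 5.2-fold higher number from compound 2 to compound 4 (0.72 log units; beyond the scatter), while the 1-carboxy-2-methylpropyl group and the chain of compound 3 do not separate, a 1.3-fold lower number from compound 3 to compound 4 (0.11 log units; within the scatter). The step of an at least 2.0-fold lower number from compound 1 to compound 4 (0.30 log units; that floor lies within the scatter) gives only a floor, so it cannot be read as a difference between 1-carboxy-2-methylpropyl and 1-(methoxycarbonyl)ethyl. Compound 1 stands at a limit and not at a number: the limit of > 50000 nM in this assay, at which 1 of the 4 values shown sits.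

Compound 2 is the only compound shown with an amine in this group, so it stays open whether the diethylamino end or the ethyl chain that carries it goes with the lower number. As far as these compounds go, how a dimethylamino end, a primary amine or a longer chain to the same diethylamino end would read is also open, as is whether a carboxylic acid and its methyl ester differ when the rest of the side chain is the same.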